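Chain Extension on the Amide Nitrogen of Compound 1

This account rests on a few compounds, and the source may have more. Where it says the series, first, only, none or still open, it means among the compounds named here.

Measured compounds:
- compound 1, `CCCCCCCCNC(=O)[C@@H](NC(=O)c1cccs1)[C@@H](C)O`: 149000 nM
- compound 2, `CCCCCCCCNC(=O)[C@@H](NC(=O)c1cc2ccccc2o1)[C@@H](C)O`: 81300 nM
- compound 3, `C/C=C/C=C/C(=O)N[C@H](C(=O)NCCCCCCCC)[C@@H](C)O`: 102000 nM

All three share one core and were read in a functional assay on HepG2 cells (Homo sapiens) for cytotoxicity, read by MTT assay, with a stated time of 48 h; a higher number here means a weaker inhibitor, a lower number a stronger inhibitor. Compound 1 shows the highest of the three numbers, but its steps to the others are small: a 1.8-fold lower number from compound 1 to compound 2 (0.26 log units; within the scatter) and a 1.5-fold lower number from compound 1 to compound 3 (0.16 log units; within the scatter), both within the scatter, as is a 1.3-fold higher number from compound 2 to compound 3 (0.10 log units; within the scatter). The three compounds therefore cannot be told apart on these data.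

Compound 4, `CCCCCCCCCCCCCCCCCCNC(=O)[C@@H](NC(=O)c1cccs1)[C@@H](C)O`, keeps the acyl group of compound 1 and changes only the chain on the other amide: decyl in place of hydrogen on a saturated chain carbon, eight bonds along the chain from an amide-type nitrogen. For the measured compounds named here, none of the measured steps touches this chain; each of them exchanges the group on the carbonyl carbon instead. Going by the values given here, there is thus no measured step that bears on the change from compound 1 to compound 4, and the expectation for compound 4 in this assay rests on compound 1 alone.

Compound 4 is estimated at 80000 nM, within a range of 15000 nM to 300000 nM, which means an expected step of a 1.9-fold lower number from compound 1 to compound 4 (0.27 log units; within the scatter) and leaves open a number close to that of compound 1.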

Compound 4, half-maximal inhibitory concentration: 92000 nM
Compound 4: the middle estimate sits 1.2-fold (0.06 log units) below what was measured; low and high end bracket the measured number.
By their numbers in this assay, from the lowest: compounds 2, 4, 3 and 1 (each within the scatter of the next).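

In this assay, the change on the chain of the other amide, decyl in place of hydrogen on a saturated chain carbon, gives a 1.6-fold lower number from compound 1 to compound 4 (0.21 log units; within the scatter). For the compounds shown here, this is the first reading at this position, and it shows that a chain lengthened by decyl cannot be told apart from compound 1 in this read-out, just as the exchanges on the carbonyl carbon could not be told apart from one another. No measured evidence is available that bears on this result.

As far as these compounds go, whether an amine or a carboxylic acid in place of decyl at this position would move the number beyond the scatter remains open. From the compounds shown here alone, it is also open whether decyl would behave the same way alongside the 1-benzofuran-2-yl of compound 2 or the penta-1,3-dien-1-yl of compound 3.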